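A few compounds are considered here, and "the series" means these few. Any claim that something is new, unique, unknown or untested is made for them only; others in the source may bear on it.

Working notes on the series. The measured set holds compound 1 `COc1ccc(/C=N/NC(=O)c2ccc(-c3ccc(Cl)cc3)nc2C)cc1OC`, compound 2 `COc1ccc(/C=N/NC(=O)c2ccc(-c3cccc(Cl)c3)nc2C)cc1` and compound 3 `COc1cc(/C=N/NC(=O)c2ccc(-c3cccc(Cl)c3)nc2C)cc(OC)c1OC`; all three share the same core and differ only in their methoxy and chloro substitution. In an ADME assay on WI-38 cells (Homo sapiens) for cytotoxicity, read by colorimetric assay and crystal violet staining, with a stated time of 24 h (a higher number here means a weaker inhibitor, a lower number a stronger inhibitor), compound 1 gives 443 ug/mL. In this assay compound 2 gives 500 ug/mL, and compound 3 gives 495 ug/mL. The three numbers lie within the scatter of one another: the nearest to compound 3 is compound 2 and the furthest is compound 1, and both gaps fall within the scatter, so compound 3 is not separated from either partner. Within the data shown here, no pair of measured compounds differs in a single place, so no measured step is available to lean on.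

Compound 4 `COc1ccc(/C=N/NC(=O)c2ccc(-c3cccc(Cl)c3)nc2C)cc1OC` is not yet measured. Relative to compound 3 it carries hydrogen in place of methoxy on an aromatic carbon. Compound 4 thus combines the methoxy pattern of compound 1 with the chloro substitution of compound 2 and compound 3. The measured values in this assay all sit in one narrow band whatever the methoxy count or chloro placement. The expectation is no step beyond the scatter in either direction. Compound 4 is expected to give about 470 ug/mL, within 330 ug/mL to 650 ug/mL. The expected step from compound 3 to compound 4 is a 1.1-fold lower number from compound 3 to compound 4 (0.02 log units; within the scatter).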

Compound 4, half-maximal inhibitory concentration: 168 ug/mL
The estimate for compound 4 lay 2.8-fold (0.45 log units) above the measured number; the measured number lies below the stated range.
By their numbers in this assay, from the lowest: compound 4; then compounds 1, 3 and 2 (each within the scatter of the next).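

In this assay the methoxy pattern now separates compounds, which the first three values did not show: hydrogen in place of methoxy gives a 2.9-fold lower number from compound 3 to compound 4 (0.47 log units; beyond the scatter) and methoxy in place of hydrogen gives a 3.0-fold lower number from compound 2 to compound 4 (0.47 log units; beyond the scatter) on the same shared core. The number therefore does not move one way with methoxy count across compounds 2, 4 and 3, since compound 4 stands lowest whether a methoxy is taken from compound 3 or added to compound 2. Among these compounds, the place of the chloro group also counts in this setting, as 3-chlorophenyl in place of 4-chlorophenyl gives a 2.6-fold lower number from compound 1 to compound 4 (0.42 log units; beyond the scatter) with the methoxy pattern held, and compound 4 is the only compound here with steps to all others beyond the scatter.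

Nothing available here accounts for any of these steps. Still open, as far as these compounds go, is whether the lower number depends on methoxy itself at this aromatic carbon or would also appear with a hydroxyl group, an ethoxy group or an amine there, and whether it would hold with the chlorine replaced by a bromine or a methyl group.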